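Replacing a fluorinated ester arm with an acid-bearing aryl arm

The compounds below may be only part of what the source reports. "The series", "measured", "known", "first", "only" and "open" are said of these compounds alone.

Of the compounds shown here, two have been tested in a functional assay on DU-145 cells (Homo sapiens) for cytotoxicity, read by trypan blue exclusion, with a stated time of 96 h; on this read-out higher numbers stand for weaker inhibition and lower numbers for stronger inhibition. Compound 1 `COc1ccc(CS(=O)(=O)/C=C/c2c(OC)cc(O)cc2OC)cc1N` gives 200 nM. Compound 2 `COC(=O)C(F)(F)Nc1cc(CS(=O)(=O)/C=C/c2c(OC)cc(OC)cc2OC)ccc1OC` gives 250 nM. Compound 2 thus sits at the upper end of the two numbers shown, but its gap to compound 1 is within the usual scatter, so the two cannot be told apart on these data.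

Compound 3 `COc1ccc(C(Nc2cc(CS(=O)(=O)/C=C/c3c(OC)cc(OC)cc3OC)ccc2OC)C(=O)O)cc1` has not yet been measured in this assay. It differs from compound 2 in one place: carboxy(4-methoxyphenyl)methyl in place of difluoro(methoxycarbonyl)methyl on a nitrogen on an aromatic ring. For the measured compounds named here, since no step between measured compounds addresses a change of this kind, the expectation rests on compound 2 alone. A step from compound 2 to compound 3 of a 1.6-fold higher number from compound 2 to compound 3 (0.20 log units; within the scatter) is expected, a moderate move toward weaker inhibition that may still lie near the scatter. Compound 3 is therefore estimated at 400 nM, with a range of 120 nM to 1500 nM.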

Compound 3, half-maximal inhibitory concentration: 100 nM
Compound 3: the middle estimate sits 4.0-fold (0.60 log units) above what was measured; measured number below the stated range.
By their numbers in this assay, from the lowest: compounds 3, 1 and 2 (each within the scatter of the next, the first and the last beyond it).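

In this assay the change of arm gives a 2.5-fold lower number from compound 2 to compound 3 (0.40 log units; beyond the scatter) and so shows that this nitrogen on an aromatic ring can carry the larger carboxy(4-methoxyphenyl)methyl, with its six-membered aromatic ring and hydrogen-bond donor, in place of difluoro(methoxycarbonyl)methyl, with a modest gain in inhibition rather than a loss. Until now, no step between measured compounds had shown how the read-out responds to any change at this position. Nothing measured here bears on why the number falls.

The new arm differs from the old in several features at once, and the compounds shown do not separate them. Going by these compounds, it stays open whether the gain follows the carboxylic acid, the 4-methoxyphenyl ring or the loss of the two fluorines, which a methyl ester of this arm or a plain phenyl ring in its place could help to tell apart.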